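A few compounds are considered here, and "the series" means these few. Any claim that something is new, unique, unknown or untested is made for them only; others in the source may bear on it.

Compound 2, `CC(C)C[C@H]1C[C@@H](Cl)C[C@@H](c2ccc([N+](=O)[O-])cc2)O1`, is the lower of the two numbers measured here, but only just: in a functional assay on WiDr cells (Homo sapiens) for antiproliferative activity (a lower number here means a stronger inhibitor of growth, a higher number a weaker inhibitor of growth), compound 2 gives 38000 nM, while compound 1, `CC(C)C[C@H]1C[C@@H](Cl)C[C@@H](c2ccccc2)O1`, gives 39000 nM. Going by the values given here, the single measured step, a 1.0-fold lower number from compound 1 to compound 2 (0.01 log units; within the scatter), is within the usual scatter, so the two compounds cannot be told apart by growth inhibition.

The next compound, compound 3, `COc1ccc([C@@H]2C[C@H](Cl)C[C@H](CC(C)C)O2)cc1`, differs from compound 2 in one place: methoxy in place of nitro on an aromatic carbon. Among the compounds with values here, the only step that bears on this change is the one at the same aromatic carbon, where a nitro group replaced hydrogen without any step beyond the scatter. With one substituent swap at that position having left the number unchanged, the expected step from compound 2 to compound 3 is no change at the digits printed from compound 2 to compound 3 (within the scatter), that is, no change beyond the scatter. Compound 3 is therefore expected to give about 38000 nM in this assay, most likely between 15000 nM and 100000 nM.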

Compound 3, concentration for 50% growth inhibition: 36000 nM
For compound 3 the middle estimate is 1.1-fold (0.02 log units) above the measured one, within the range that was stated.
By their numbers in this assay, from the lowest: compounds 3, 2 and 1 (each within the scatter of the next).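

In this assay, methoxy in place of nitro on this aromatic carbon (a 1.1-fold lower number from compound 2 to compound 3 (0.02 log units; within the scatter)) and methoxy in place of hydrogen (a 1.1-fold lower number from compound 1 to compound 3 (0.03 log units; within the scatter)) both stay within the scatter. Hydrogen, nitro and methoxy, which differ in their atoms and in their count of hydrogen-bond acceptors, therefore cannot be told apart here by growth inhibition, whereas the earlier step compared only nitro with hydrogen. No measurement offered here explains this result.

As far as these compounds go, whether any other group on this carbon, such as an amine, a carboxylic acid or a longer chain, would move the number beyond the scatter remains open. From the compounds shown here alone, the chlorine and the rest of the shared core are the same in all three compounds, so the effect of changes there also remains open.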